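This account rests on a few compounds, and the source may have more. Where it says the series, first, only, none or still open, it means among the compounds named here.

Measured so far in a functional assay on HCT-116 cells (Homo sapiens) for cytotoxicity, read by sulforhodamine B assay, with a stated time of 48 h; a higher number here means a weaker inhibitor, a lower number a stronger inhibitor:

compound 1 `CO[C@@H]1CC=C2NN(c3c[nH]c4ccccc34)C(=O)CC[C@]2(c2ccccc2)O1` — 1100 nM
compound 2 `CO[C@@H]1CC=C2NN(c3cc(Cl)cc(Cl)c3)C(=O)CC[C@]2(c2ccccc2)O1` — 6520 nM
compound 3 `CO[C@@H]1CC=C2N(c3ccc(C)cc3)C(=O)C[C@]2(c2ccccc2)O1` — 4300 nM

Compound 3 stands second highest of the three numbers in this assay. Its nearest neighbour is compound 2, whose number is within the scatter of it, so the two cannot be ordered; compound 1 sits further off with a lower number, beyond the scatter.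

The next compound, compound 4 `CO[C@@H]1CC=C2N(c3cc(Cl)cc(Cl)c3)C(=O)C[C@]2(c2ccccc2)O1`, differs from compound 3 in one place: 3,5-dichlorophenyl in place of 4-methylphenyl on an amide-type nitrogen in a ring. For the measured compounds named here, no measured pair carries exactly this exchange. Going by the values given here, the one step that touches the entering group is a 5.9-fold higher number from compound 1 to compound 2 (0.77 log units; beyond the scatter), where the same 3,5-dichlorophenyl replaced 1H-indol-3-yl, on a different core and against a different leaving group. That step pushed the number up by a modest amount. Taken as a loose guide, a small rise in this assay, or none beyond the scatter, is the likely outcome here; the leaving 4-methylphenyl of compound 3 is not itself anchored by any measured step.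

For compound 4 the estimated step is a 1.4-fold higher number from compound 3 to compound 4 (0.14 log units; within the scatter), and the expected value in this assay is 6000 nM, with a range from 2500 nM to 15000 nM.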

Compound 4, half-maximal inhibitory concentration: 11200 nM
Compound 4: the middle estimate sits 1.9-fold (0.27 log units) below what was measured; low and high end bracket the measured number.
By their numbers in this assay, from the lowest: compound 1; then compounds 3, 2 and 4 (each within the scatter of the next, the first and the last beyond it).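

In this assay, for the compounds shown here, a 2.6-fold higher number from compound 3 to compound 4 (0.42 log units; beyond the scatter) is the only measured exchange on the amide-type nitrogen of the five-membered ring, and it shows that this position responds to the choice of aryl group even though both groups have one six-membered aromatic ring of carbon only and neither has hydrogen-bond donors or acceptors. Read with a 5.9-fold higher number from compound 1 to compound 2 (0.77 log units; beyond the scatter), 3,5-dichlorophenyl now goes with a higher number in both available pairs, on two different cores and against two different leaving groups, though two pairs are too few to establish a general pattern. No measured evidence accounts for the rise at this position.

The compounds shown leave open whether the higher number in compound 4 tracks the two chlorine atoms together, or whether a single chlorine on the phenyl ring would give a similar result. They also leave open whether a phenyl ring carrying an amine or a carboxylic acid on this nitrogen would bring the number down, and whether 1H-indol-3-yl would hold its low number on the core of compound 3.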